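Swapping the hydroxyethyl side chain for isobutyl

The compounds below may be only part of what the source reports. "The series", "measured", "known", "first", "only" and "open" are said of these compounds alone.

Three analogues built on one shared core have been measured in a functional assay on the whole organism (Tail, strain ICR) with Mus musculus as the target, in the tail flick test, with a stated time of 90 min, at a dose of 25 umol/kg by the oral route; a higher number here means a stronger effect of the compound at the dose given, a lower number a weaker effect. Compound 1 `C[C@@H](O)[C@H](NC(=O)CN(c1nc(Cl)nc2[nH]cnc12)C1CC1)C(=O)O` gives 35.9% in this assay. Compound 2 `O=C(CN(c1nc(Cl)nc2[nH]cnc12)C1CC1)N[C@@H](CCC(=O)OCc1ccccc1)C(=O)OCc1ccccc1` gives 50% in this assay, and compound 3 `NC(=O)CC[C@H](NC(=O)CN(c1nc(Cl)nc2[nH]cnc12)C1CC1)C(=O)OCc1ccccc1` gives 42.8% in this assay. Of these three numbers, compound 1 stands lowest: its gap to compound 3 lies within the usual scatter, whereas its gap to compound 2 lies beyond it. Within the data shown here, only one pair of measured compounds differs in a single place, and that step, a number 7.2 percentage points lower from compound 2 to compound 3 (within the scatter), concerns a change on a carbonyl carbon far from the side chain considered here.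

Compound 4 `CC(C)C[C@H](NC(=O)CN(c1nc(Cl)nc2[nH]cnc12)C1CC1)C(=O)O` differs from compound 1 in one place: isobutyl in place of 1-hydroxyethyl on a saturated chain carbon bound to an amide-type nitrogen and a carbonyl carbon. Among the measured compounds shown here, no measured step bears on this position, so the measured set gives no direct guide; the one single-place step recorded anywhere stayed within the scatter. On that basis a change beyond the scatter is not expected, though the uncertainty is wide. Compound 4 is estimated to give about 40% in this assay, within a range of 24% to 58%. This estimate means a step of a number 4.1 percentage points higher from compound 1 to compound 4 (within the scatter) is expected.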

Compound 4, a percentage reported as activity, at one dose (the size of the read-out at that dose, not a potency): 27%
For compound 4 the middle estimate is 13 percentage points above the measured one; the range from low to high includes it.
By their numbers in this assay, from the lowest: compounds 4, 1, 3 and 2 (each within the scatter of the next, the first and the last beyond it).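

Among these compounds, this step is the first reading at this position, on the saturated chain carbon bound to an amide-type nitrogen and a carbonyl carbon, and in this assay it reads a number 8.9 percentage points lower from compound 1 to compound 4 (within the scatter). Isobutyl has no hydrogen-bond donor or acceptor, whereas the 1-hydroxyethyl group it replaces has one of each, so with these two compounds the read-out at this dose does not depend measurably on the presence of that oxygen or the stereocentre within the side chain. Nothing measured on these compounds offers an explanation of the step, and its size gives no ground for assigning it to any feature of either group.

As far as these compounds go, it remains open whether a side chain of another kind on this carbon, such as an amine, a carboxylic acid, a phenyl ring or a longer chain, would move the read-out beyond the scatter. From the compounds shown here alone, since the read-out gives the size of the effect at one dose and one time rather than a potency, it also remains open whether compound 1 and compound 4 would stay this close at other doses or times.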